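A few compounds are considered here, and "the series" means these few. Any claim that something is new, unique, unknown or untested is made for them only; others in the source may bear on it.

Measured in a functional assay on HUVEC cells (Homo sapiens) for inhibition; on this read-out higher numbers stand for weaker inhibition and lower numbers for stronger inhibition:
- compound 1 `CN(c1ccc(NC(=N)Nc2ccccc2)cc1)c1ccnc(Nc2cccc(CS(C)(=O)=O)c2)n1`: 596 nM
- compound 2 `CN(c1ccc(NC(=O)Nc2ccccc2)cc1)c1ccnc(Nc2cccc(S(N)(=O)=O)c2)n1`: 2 nM

Of these two numbers, compound 1 holds the higher, at 596 nM, and the gap to compound 2 lies beyond the scatter. Compound 3 `CCCCNC(=O)Nc1ccc(N(C)c2ccnc(Nc3cccc(CS(C)(=O)=O)c3)n2)cc1` has not yet been measured. Relative to compound 1 it carries butylcarbamoyl on a nitrogen on an aromatic ring: a group of 7 heavy atoms (5 carbon, 1 nitrogen, 1 oxygen; no ring) in place of a group of 9 heavy atoms (7 carbon, 2 nitrogen; one six-membered aromatic ring of carbon only), on a nitrogen on an aromatic ring.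

For the measured compounds named here, no measured step isolates this change. Compound 2, at 2 nM, differs from compound 1 in more than one place, so its low number offers only weak guidance. A moderate move toward stronger inhibition in this assay, beyond the scatter, is expected, and the expected step is a 4.0-fold lower number from compound 1 to compound 3 (0.60 log units; beyond the scatter). For compound 3 the estimated value is 150 nM, with an expected range of 30 nM to 700 nM.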

Compound 3, half-maximal inhibitory concentration: 2 nM
The estimate for compound 3 lay 75-fold (1.88 log units) above the measured number; the measured number lies below the stated range.
By their numbers in this assay, from the lowest: compounds 2 and 3 (each within the scatter of the next); then compound 1.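

In this assay, putting butylcarbamoyl in place of the earlier group, on a nitrogen on an aromatic ring, gives a 300-fold lower number from compound 1 to compound 3 (2.47 log units; beyond the scatter), a large step beyond the scatter. For the compounds shown here, with the rest of compound 1 unchanged, this single place is therefore enough to move the number strongly, which the earlier compounds could not show. The entering group has no ring, so strong inhibition at this position does not require the six-membered aromatic ring of the leaving group. Nothing at hand explains the size of this step.

Going by these compounds, the step exchanges the whole group at once, so it remains open whether the carbonyl or the butyl chain accounts for the change. Also open, on these data alone, is how a propyl chain, a longer chain or a terminal amine would read at this position.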